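Methyl for cyclopropyl on the sulfonyl sulfur: stability

This account rests on a few compounds, and the source may have more. Where it says the series, first, only, none or still open, it means among the compounds named here.

Measured in an ADME assay on microsomes from liver (Rattus norvegicus) for metabolic stability, with a stated time of 10 min, tested at 0.5 uM; on this read-out lower numbers stand for a less stable compound and higher numbers for a more stable compound:
compound 1 `Cn1cc(-c2ccc(C(F)(F)F)cc2)c2cc(F)c(C(=O)NS(=O)(=O)C3CC3)cc21` gives 100%
compound 2 `CC(C)COc1ncc(-c2cn(C)c3cc(C(=O)NS(=O)(=O)C4CC4)c(F)cc23)cc1Cl` gives 37%
compound 3 `CC(C)COc1ncc(-c2cn(C)c3cc(C(=O)NS(C)(=O)=O)c(F)cc23)cc1Cl` gives 85%

Compound 2 and compound 3 share a core and differ by one change, (methyl in place of cyclopropyl on a sulfonyl sulfur), which brought a number 48 percentage points higher from compound 2 to compound 3 (beyond the scatter) in this assay. The same change, (methyl in place of cyclopropyl on a sulfonyl sulfur), turns compound 1 into the unmeasured compound 4 `Cn1cc(-c2ccc(C(F)(F)F)cc2)c2cc(F)c(C(=O)NS(C)(=O)=O)cc21`; the place is the same in words in both pairs. How the core of compound 1 differs from that of compound 2 is not broken down here; their values alone show compound 1 standing well above compound 2 in this assay, while compound 3 sits closer to compound 1.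

The step from compound 2 to compound 3 was large, but compound 1 already sits at the top of what this assay can report, so the expected step from compound 1 to compound 4 is a number 3 percentage points lower from compound 1 to compound 4 (within the scatter), resting on compound 1 giving 100% and on the rise seen in a number 48 percentage points higher from compound 2 to compound 3 (beyond the scatter). Compound 4 is therefore estimated at 97%, between 87% and 100%.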

Compound 4, percent of the compound remaining: 99%
Compound 4: middle estimate off by 2 percentage points, on the low side; low and high end bracket the measured number.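

In this assay, putting methyl in place of cyclopropyl on the sulfonyl sulfur of the core of compound 1 gave a number 1 percentage points lower from compound 1 to compound 4 (within the scatter), so this pair shows no change that can be told from scatter. The size of the step therefore did not carry over from one core to the other: the same change on two cores in this assay, a number 48 percentage points higher (beyond the scatter) from compound 2 to compound 3 and a number 1 percentage points lower (within the scatter) from compound 1 to compound 4, 49 percentage points apart, beyond the scatter of two such steps This does not show that the change has no effect on the core of compound 1, since compound 1 gives 100%, the top of what this read-out can report, which leaves no room for a rise to appear, and it does not explain why the two pairs differ.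

For the compounds shown here, with only two pairs, it remains open how the change behaves on a core whose cyclopropyl compound starts somewhere between these two values. Also open, going by these compounds, is whether a longer chain or an amine on the sulfonyl sulfur would follow methyl or cyclopropyl on either core.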